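Working notes: from methoxycarbonyl to carbamoyl

The compounds below may be only part of what the source reports. "The series", "measured", "known", "first", "only" and "open" are said of these compounds alone.

Measured in an ADME assay on Jurkat cells (Homo sapiens) for cytotoxicity, read by MTT assay, with a stated time of 72 h; a higher number here means a weaker inhibitor, a lower number a stronger inhibitor:
- compound 1 `COC(=O)c1ccc(Oc2ccc3c(c2)B(O)OC3)cn1` gives > 100000 nM (a limit of the assay)
- compound 2 `O=C(O)c1cnc(Oc2ccc3c(c2)B(O)OC3)cn1` gives > 100000 nM (a limit of the assay)
- compound 3 `COC(=O)c1cnc(Oc2ccc3c(c2)B(O)OC3)cn1` gives 7590 nM (a number)

Not yet measured: compound 4 `NC(=O)c1cnc(Oc2ccc3c(c2)B(O)OC3)cn1`.

Going by the values given here, compound 3 holds the only number. Compound 1 and compound 2 stand at the limit of > 100000 nM in this assay, at which 2 of the 3 values shown sit, and so give no number to compare with it.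

The next step replaces the group on the carbonyl of compound 3 to give compound 4: amino in place of methoxy on a carbonyl carbon, that is, methoxycarbonyl to carbamoyl (amino in place of methoxy on a carbonyl carbon).

Among the compounds with values here, one measured step bears on this carbonyl: an at least 13-fold lower number from compound 2 to compound 3 (1.11 log units; beyond the scatter) in a large change. It shows that the group on this carbonyl can matter a great deal here, but its true size is open, since one end is a limit. Amino is a different group from the hydrogen of compound 2, so only part of that size is carried over.

Expected in this assay is a 4.6-fold higher number from compound 3 to compound 4 (0.66 log units; beyond the scatter) on the side of the higher number, smaller than the measured step. The estimated value for compound 4 is 35000 nM (expected range 10000 nM to 100000 nM), and a reading at the limit remains possible.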

Compound 4, half-maximal inhibitory concentration: 48200 nM
Estimate against measurement, compound 4: 1.4-fold (0.14 log units) below; the measured number falls inside the stated range.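

In this assay, this carbonyl now has two groups that both give a number, and the comparison between them can be read in full: a 6.4-fold higher number from compound 3 to compound 4 (0.80 log units; beyond the scatter). Methoxy and amino are therefore not interchangeable at this place, although the amino compound still stays clear of the limit reached by compound 2, as shown by an at least 2.0-fold lower number from compound 2 to compound 4 (0.31 log units; beyond the scatter). Across compound 2, compound 3 and compound 4, the number is lowest with methoxy, intermediate with amino and highest with hydroxy, so the group on the carbonyl orders all three compounds, with the hydroxy end fixed only by a limit.

The full distance from hydroxy to either of the other two groups cannot be read, and that applies to every step that starts from that end: the limit of > 100000 nM in this assay, at which 2 of the 4 values shown sit. The compounds shown leave open how methylamino, dimethylamino or a longer ethoxy chain on this carbonyl would read, and whether the same order would hold on the core of compound 1, which carries methoxycarbonyl and also stands at a limit.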